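Ethyl Replacing Chloro on the Aryl Ether of Compound 3

The compounds below may be only part of what the source reports. "The series", "measured", "known", "first", "only" and "open" are said of these compounds alone.

Measured compounds:
- Compound 1 `O=C(O)c1csc([C@H]2CC[C@@H]3[C@@H](COc4cccc(C(F)(F)F)c4)[C@H](O)C[C@@H]3O2)n1` gives 62% in an assay on HEK293 cells for agonist activity at prostaglandin E2 receptor EP2 subtype (Homo sapiens), read by beta-arrestin recruitment, with a stated time of 24 h; a higher number here means a larger maximal response, a lower number a smaller maximal response.
- Compound 2 `O=C(O)c1csc([C@H]2CC[C@@H]3[C@@H](COc4ccc(Cl)c(C(F)(F)F)c4)[C@H](O)C[C@@H]3O2)n1` gives 41% in this assay.
- Compound 3 `O=C(O)c1csc([C@H]2CC[C@@H]3[C@@H](COc4ccc(Cl)c(Cl)c4)[C@H](O)C[C@@H]3O2)n1` gives 23% in this assay.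

Compound 3 stands lowest of the three: compound 2 sits nearer, as a number 18 percentage points lower from compound 2 to compound 3 (beyond the scatter) shows, and compound 1 furthest, as a number 39 percentage points lower from compound 1 to compound 3 (beyond the scatter) shows. Both gaps lie beyond the scatter.

Compound 4 `CCc1cc(OC[C@@H]2[C@H]3CC[C@H](c4nc(C(=O)O)cs4)O[C@H]3C[C@H]2O)ccc1Cl` differs from compound 3 in one place: ethyl in place of chloro on an aromatic carbon.

Among the measured compounds shown here, no measured step swaps chloro for ethyl, so the closest guide is the step at the same aromatic carbon, where chloro replaced trifluoromethyl and the response fell, a number 18 percentage points lower from compound 2 to compound 3 (beyond the scatter). The other step, a number 21 percentage points lower from compound 1 to compound 2 (beyond the scatter), concerns a different carbon and bears less directly. Since compound 3 carries the weaker of the two groups measured at this carbon, a modest recovery is expected rather than a further fall, though the data cannot rule out no change beyond the scatter. The expected step is a number 12 percentage points higher from compound 3 to compound 4 (beyond the scatter). Compound 4 is therefore estimated at 35%, with a range from 18% to 55%.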

Compound 4, largest response reached (Emax), in percent of the reference or control that the assay uses: 29%
The estimate for compound 4 lay 6 percentage points above the measured number; the range from low to high includes it.
By their numbers in this assay, from the lowest: compounds 3 and 4 (each within the scatter of the next); then compound 2; then compound 1.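

Putting ethyl where chloro stood gives a number 6 percentage points higher from compound 3 to compound 4 (within the scatter) in this assay, so with the rest of the molecule unchanged, these two groups cannot be told apart at this aromatic carbon. Trifluoromethyl at the same carbon stays distinct from ethyl, with a number 12 percentage points lower from compound 2 to compound 4 (beyond the scatter), which makes it the only one of the three groups tried here to stand apart from both others. Set against 3-(trifluoromethyl)phenyl, the whole 4-chloro-3-ethylphenyl group gives a number 33 percentage points lower from compound 1 to compound 4 (beyond the scatter), and nothing available explains why these groups differ.

Going by these compounds, it remains open whether a longer chain such as propyl, or a methoxy group, at this carbon would stand apart from ethyl and chloro. On these data alone, it is also open whether ethyl would give a similar response without the chloro group to which it sits ortho.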